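Intrinsic activity in the shared-core series: compound 4

The source may hold more compounds than are shown below. What is called first, only, known or untested is meant among the compounds shown, and "the series" means these compounds.

Of the compounds shown here, three on a shared core have been measured in a functional assay on Right cardiac atrium for agonist activity at histamine H2 receptor (Cavia porcellus), with a stated time of 30 min, in the presence of a further agent that is not named here; on this read-out higher numbers stand for larger maximal responses and lower numbers for smaller maximal responses. Compound 1 `Cc1nc(N)sc1CCCN/C(N)=N/C(=O)NC(C)c1ccc(OC(F)(F)F)cc1` gives 0.61. Compound 2 `COc1ccc(C(C)NC(=O)/N=C(\N)NCCCc2sc(N)nc2C)cc1` gives 0.91. Compound 3 `Cc1nc(N)sc1CCCN/C(N)=N/C(=O)NC(C)c1ccco1` gives 1, the highest of the three numbers, though it sits within the scatter of compound 2 and only beyond the scatter against compound 1. The two connecting steps are a number 0.30 higher from compound 1 to compound 2 (beyond the scatter) and a number 0.090 higher from compound 2 to compound 3 (within the scatter).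

Compound 4 `Cc1nc(N)sc1CCCN/C(N)=N/C(=O)NC(C)c1ccc(F)cc1` awaits measurement in this assay. It differs from compound 3 by 4-fluorophenyl in place of furan-2-yl on a saturated chain carbon bound to an amide-type nitrogen and a saturated chain carbon. Both measured steps bear on this change. The exchange of one aromatic group for another at the same place, between compound 2 and compound 3, stayed within the scatter. The change of the group on the oxygen of the aromatic ring, between compound 1 and compound 2, was modest but beyond the scatter, so the nature of the single substituent on a six-membered ring does move the number. A fluorine substituent is unmeasured, so the expectation for compound 4 lies between compound 1 and compound 3, nearer the latter: compound 4 is expected to give 0.85, with a range of 0.65 to 1. The step this estimate means, a number 0.15 lower from compound 3 to compound 4 (beyond the scatter), is expected to be small and downward, possibly within the scatter.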

Compound 4, intrinsic activity: the largest response reached, as a fraction of the reference agonist's: 0.92
Compound 4: middle estimate off by 0.070, on the low side, within the range that was stated.
By their numbers in this assay, from the lowest: compound 1; then compounds 2, 4 and 3 (each within the scatter of the next).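

In this assay, 4-fluorophenyl in place of furan-2-yl on a saturated chain carbon bound to an amide-type nitrogen and a saturated chain carbon is a number 0.080 lower from compound 3 to compound 4 (within the scatter) and so does not separate a five-membered aromatic ring with one hetero atom from a six-membered aromatic ring of carbon only at this place. On the aromatic carbon, fluoro in place of methoxy is a number 0.010 higher from compound 2 to compound 4 (within the scatter) while fluoro in place of trifluoromethoxy is a number 0.31 higher from compound 1 to compound 4 (beyond the scatter) and so, of the three substituents on this ring, only the trifluoromethoxy of compound 1 is set apart, with methoxy and fluoro not told apart. Nothing available here accounts for why trifluoromethoxy alone stands apart.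

From the compounds shown here alone, whether an amine or a carboxylic acid in place of fluoro on the aromatic carbon would stay with compound 2 and compound 4 or move toward compound 1 remains open. Also open is whether a longer chain on the saturated chain carbon would leave the maximal response unchanged, and only maximal response is shown, so nothing can be said of potency across the series.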